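Adding a second methoxy group to compound 2

The source may hold more compounds than are shown below. What is called first, only, known or untested is meant among the compounds shown, and "the series" means these compounds.

Values measured in a functional assay on the whole organism (strain Sprague-Dawley) for inhibition, with Rattus norvegicus as the target, with a stated time of 10 min; on this read-out higher numbers stand for an effect only at larger amounts of compound and lower numbers for an effect already at smaller amounts:
Compound 1 `Nc1ccccc1-c1ncc(C(=O)O)c(=O)[nH]1` gives 50 mg/kg
Compound 2 `COc1ccccc1-c1ncc(C(=O)O)c(=O)[nH]1` gives 10 mg/kg
Compound 3 `CCCCOc1ccccc1-c1ncc(C(=O)O)c(=O)[nH]1` gives 0.5 mg/kg

Compound 2 holds the middle place among these three numbers, with compound 1 higher and compound 3 lower. A lower number here means that a smaller dose is enough. Compound 4 `COc1ccc(-c2ncc(C(=O)O)c(=O)[nH]2)c(OC)c1` differs from compound 2 by a single change (methoxy in place of hydrogen on an aromatic carbon): methoxy in place of hydrogen on an aromatic carbon, meta to a methoxy group and para to a large group.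

Going by the values given here, two measured steps bear on this only indirectly. Replacing amino with methoxy gave a modest step (a 5.0-fold lower number from compound 1 to compound 2 (0.70 log units; beyond the scatter)), and replacing a hydrogen of the methoxy group with propyl gave a large one (a 20-fold lower number from compound 2 to compound 3 (1.30 log units; beyond the scatter)). Among the compounds with values here, both alter the one group already on the ring, and no measured compound carries a second group there. They show that this assay responds to changes on this ring, but they give no direction for this new change. The expected step is small, estimated as a 1.3-fold lower number from compound 2 to compound 4 (0.10 log units; within the scatter) and probably within the scatter. Compound 4 is expected at 8 mg/kg (estimated range 2 mg/kg to 30 mg/kg).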

Compound 4, dose for 50% inhibition: 5 mg/kg
Estimate against measurement, compound 4: 1.6-fold (0.20 log units) above; low and high end bracket the measured number.
By their numbers in this assay, from the lowest: compound 3; then compounds 4 and 2 (each within the scatter of the next); then compound 1.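

In this assay, adding a methoxy group at this place, meta to a methoxy group and para to a large group, gives a 2.0-fold lower number from compound 2 to compound 4 (0.30 log units; within the scatter), so the number does not shift by more than the usual variation between repeats. Compound 4 is the only compound shown with a second group on this ring, and it shows that the ring can carry one here and keep the effect in the same dose range, whereas the earlier steps only altered the one group already present. Nothing available explains this result.

From the compounds shown here alone, whether a different group at this place, such as a hydroxyl, a chlorine atom or a longer chain, would move the number beyond the scatter stays open. Going by these compounds, it is also open whether this added methoxy group would behave the same way alongside the butoxy group of compound 3.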